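The compounds below may be only part of what the source reports. "The series", "measured", "known", "first", "only" and "open" are said of these compounds alone.

Series notes. Going by the values given here, compound 1 `COc1ccccc1-c1cc(/C=C/c2ccc(C(=O)NO)cc2)ccn1` is the only member with a numerical value in a functional assay on HCT-116 cells (Homo sapiens) for antiproliferative activity, read by CellTiter-Glo, with a stated time of 72 h; on this read-out higher numbers stand for weaker inhibition and lower numbers for stronger inhibition: compound 1 gives 8440 nM. The other measured member, compound 2 `Cc1ccc(-c2cc(/C=C/c3ccc(C(=O)NO)cc3)c(F)cn2)cc1`, returns only a limit of the assay in this assay, namely > 10000 nM. One of the two values shown therefore sits at the limit of > 10000 nM in this assay, at which 1 of the 2 values shown sits. Among the compounds with values here, no step between two measured compounds that differ in one place is available, so no measured step sets the scale of change for the series.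

Compound 3 `O=C(NO)c1ccc(/C=C/c2ccnc(-c3ccsc3)c2)cc1` remains to be measured. Relative to compound 1 the change is thiophen-3-yl in place of 2-methoxyphenyl on an aromatic carbon. Within the data shown here, with no measured step to lean on, the expectation for compound 3 rests on compound 1 alone. The expected step for compound 3 is a 1.1-fold lower number from compound 1 to compound 3 (0.02 log units; within the scatter), none beyond the scatter. Compound 3 is estimated to give about 8000 nM in this assay, with a range from 3000 nM to 20000 nM.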

Compound 3, half-maximal inhibitory concentration: 1910 nM
For compound 3 the middle estimate is 4.2-fold (0.62 log units) above the measured one; measured number below the stated range.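

In this assay, going by these compounds alone, the position next to the ring nitrogen responds to the group it carries: thiophen-3-yl in place of 2-methoxyphenyl gives a 4.4-fold lower number from compound 1 to compound 3 (0.65 log units; beyond the scatter), the first measured step and one beyond the scatter. The entering group has 5 heavy atoms against 8 for the leaving one, while each has 1 hydrogen-bond acceptor, so the acceptor count does not separate the pair, and ring size, hetero atom and the methoxy group all change in this single step. Compound 2 adds no comparison, as its value is a limit of the assay: the limit of > 10000 nM in this assay, at which 1 of the 3 values shown sits.

The compounds shown leave open whether the lower number follows the sulfur, the five-membered ring or the loss of the methoxy group. As far as these compounds go, how an unsubstituted phenyl, a furan-3-yl or an amine at this position would read in this assay also remains open.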